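A few compounds are considered here, and "the series" means these few. Any claim that something is new, unique, unknown or untested is made for them only; others in the source may bear on it.

Measured so far in a functional assay on B16 cells (Mus musculus) for cytotoxicity, read by MTT assay, with a stated time of 72 h; a higher number here means a weaker inhibitor, a lower number a stronger inhibitor:
Compound 1 `Cc1ccc(COc2cc(O)c3c(=O)cc(-c4ccccc4)oc3c2OCCCCN2CCN(C)CC2)cc1` gives 3290 nM.
Compound 2 `CN1CCN(CCCCOc2c(OCc3ccc(C#N)cc3)cc(O)c3c(=O)cc(-c4ccccc4)oc23)CC1` gives 3700 nM.
Compound 3 `CN1CCN(CCCCOc2c(OCc3nc4ccccc4o3)cc(O)c3c(=O)cc(-c4ccccc4)oc23)CC1` gives 2080 nM.

Compound 3 has the lowest of the three numbers, but the steps of a 1.6-fold lower number from compound 1 to compound 3 (0.20 log units; within the scatter) and a 1.8-fold lower number from compound 2 to compound 3 (0.25 log units; within the scatter) both lie within the scatter, as does a 1.1-fold higher number from compound 1 to compound 2 (0.05 log units; within the scatter), so the three compounds cannot be separated. Compound 4 `CN1CCN(CCCCOc2c(OCc3nc4ccccc4s3)cc(O)c3c(=O)cc(-c4ccccc4)oc23)CC1` differs from compound 3 in one place: 1,3-benzothiazol-2-yl in place of 1,3-benzoxazol-2-yl on a saturated chain carbon bound to an oxygen on an aromatic ring. Going by the values given here, no measured step exchanges these two groups. The nearest guidance comes from the steps that replaced the whole group at this place, a 1.6-fold lower number from compound 1 to compound 3 (0.20 log units; within the scatter) and a 1.8-fold lower number from compound 2 to compound 3 (0.25 log units; within the scatter), and both stayed within the scatter. A step no larger than the scatter is therefore expected in this assay, with no direction; compound 4 is estimated at 2000 nM (range 900 nM to 4500 nM), which means an expected step of a 1.0-fold lower number from compound 3 to compound 4 (0.02 log units; within the scatter).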

Compound 4, half-maximal inhibitory concentration: 2780 nM
Compound 4: middle estimate off by 1.4-fold (0.14 log units), on the low side, and the stated range covers the measured number.
By their numbers in this assay, from the lowest: compounds 3, 4, 1 and 2 (each within the scatter of the next).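

In this assay, exchanging 1,3-benzoxazol-2-yl for 1,3-benzothiazol-2-yl, which changes one ring oxygen to sulfur, stays within the scatter (a 1.3-fold higher number from compound 3 to compound 4 (0.13 log units; within the scatter)). 1,3-Benzothiazol-2-yl also cannot be separated from 4-cyanophenyl (a 1.3-fold lower number from compound 2 to compound 4 (0.12 log units; within the scatter)) or 4-methylphenyl (a 1.2-fold lower number from compound 1 to compound 4 (0.07 log units; within the scatter)). All four groups at this place, including two closely matched ring systems, therefore give numbers within the scatter of one another. Whether a group carrying an amine or a carboxylic acid here would produce a step beyond the scatter remains open, and no supporting measurement is available to explain these numbers.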